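Third Aryl Variant in a Cytotoxicity Series

A few compounds are considered here, and "the series" means these few. Any claim that something is new, unique, unknown or untested is made for them only; others in the source may bear on it.

Compound 1 `COc1cc(/C=N/NC(=O)Nc2ccc(Oc3ccnc(-c4nncn4CCN(C)C)c3)c(F)c2)cc(OC)c1OC` gives 3620 nM in a functional assay on HT-29 cells (Homo sapiens) for cytotoxicity, read by MTT assay, with a stated time of 72 h; on this read-out higher numbers stand for weaker inhibition and lower numbers for stronger inhibition.
Compound 2 `CN(C)CCn1cnnc1-c1cc(Oc2ccc(NC(=O)N/N=C/c3cc(Br)c(O)c(Br)c3)cc2F)ccn1` gives 2670 nM in this assay.

Compound 2 sits at one end of these two numbers, separated from compound 1 by a 1.4-fold lower number from compound 1 to compound 2 (0.13 log units; within the scatter). Compound 3 `CN(C)CCn1cnnc1-c1cc(Oc2ccc(NC(=O)N/N=C/c3ccc(F)cc3Cl)cc2F)ccn1` carries 2-chloro-4-fluorophenyl in place of 3,5-dibromo-4-hydroxyphenyl on a carbon with a double bond to nitrogen. Among the measured compounds shown here, the only measured step that bears on this change is the earlier aryl swap, which stayed within the scatter. The step expected in this assay is therefore a 1.0-fold higher number from compound 2 to compound 3 (0.02 log units; within the scatter), none beyond the scatter. Compound 3 is estimated at 2800 nM, within a range from 900 nM to 9000 nM.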

Compound 3, half-maximal inhibitory concentration: 510 nM
Estimate against measurement, compound 3: 5.5-fold (0.74 log units) above; the whole stated range lies above it.
By their numbers in this assay, from the lowest: compound 3; then compounds 2 and 1 (each within the scatter of the next).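

With 2-chloro-4-fluorophenyl on the carbon with a double bond to nitrogen, this assay shows a 5.2-fold lower number from compound 2 to compound 3 (0.72 log units; beyond the scatter) and also a 7.1-fold lower number from compound 1 to compound 3 (0.85 log units; beyond the scatter) for this change. Among the compounds shown here, the earlier aryl swap stayed within the scatter, so this is the first sign that the group at this place can move the number beyond it. Nothing shown explains the size of these steps.

Which part of the new group carries the step stays open, as chlorine and fluorine appear only together. A phenyl carrying only one of them, or an aryl group bearing an amine, would begin to separate these effects.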